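Compound 2 and its double-bond isomer

This account rests on a few compounds, and the source may have more. Where it says the series, first, only, none or still open, it means among the compounds named here.

Compound 1 `CC/C(=C(/c1ccccc1)c1ccc(NC(=O)C(C)C)cc1)c1ccccc1`: > 30000 nM (a limit)
Compound 2 `CC/C(=C(\c1ccc(O)cc1)c1ccc(NC(=O)C(C)C)cc1)c1ccccc1`: 14700 nM

Among the compounds with values here, in a functional assay on MCF7 cells (Homo sapiens) for inhibition, read by trypan blue exclusion, with a stated time of 72 h (a higher number here means a weaker inhibitor of growth, a lower number a stronger inhibitor of growth), compound 2 gives 14700 nM, the only actual number so far. Compound 1 gives > 30000 nM, which is a limit of the assay. Compound 3 `CC/C(=C(/c1ccc(O)cc1)c1ccc(NC(=O)C(C)C)cc1)c1ccccc1` differs from compound 2 in configuration only: the two compounds have the same atoms and bonds and differ only in configuration as drawn: 1 of 1 stereo elements differ; a double bond is drawn E in compound 2 and Z in compound 3. Within the data shown here, no measured pair shows the size of such a change, so no step beyond the scatter is expected in this assay, in either direction. The expected step is a 1.0-fold higher number from compound 2 to compound 3 (0.01 log units; within the scatter). For compound 3 the estimated value is 15000 nM, with an expected range of 6000 nM to 30000 nM.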

Compound 3, concentration for 50% growth inhibition: 16400 nM
Beside the measured number, compound 3's estimate is 1.1-fold (0.04 log units) below it; measured number inside the range.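

In this assay, within the data shown here, the first measured pair for double-bond configuration gives a 1.1-fold higher number from compound 2 to compound 3 (0.05 log units; within the scatter), so swapping E for Z at this double bond shows no step beyond the scatter. Hydroxy in place of hydrogen on an aromatic carbon gives an at least 1.8-fold lower number from compound 1 to compound 3 (0.26 log units; that floor lies within the scatter), so no step beyond the scatter can be read for this change. That comparison rests on a limit and not on a number: the limit of > 30000 nM in this assay, at which 1 of the 3 values shown sits.

Still open, going by these compounds, is whether an amine or a carboxylic acid in place of the hydroxy would move the number beyond the scatter. Also open, on these data alone, is whether double-bond configuration would matter with such a group.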